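The source may report more compounds than this note shows. Statements on the series, on what has been measured and on what is new or still open speak of the compounds shown alone.

Three members of the series have been run in an assay on membranes from liver for displacement of a labelled ligand from Sigma non-opioid intracellular receptor 1 (Rattus norvegicus), read by scintillation counting; a lower number here means a stronger inhibitor, a higher number a weaker inhibitor. Compound 1 `Cc1ccc(CN(C)CCCn2c(=O)oc3ccccc32)c(C)c1` gives 1830 nM, compound 2 `CN(CCCn1c(=O)oc2ccccc21)Cc1ccc(Cl)cc1` gives 1150 nM, and compound 3 `CN(CCCn1c(=O)oc2ccccc21)Cc1cccc(Cl)c1` gives 3230 nM. Compound 3 has the highest of the three numbers; its nearest neighbour is compound 1, a 1.8-fold higher number from compound 1 to compound 3 (0.25 log units; within the scatter), while the gap to compound 2, a 2.8-fold higher number from compound 2 to compound 3 (0.45 log units; beyond the scatter), lies beyond the scatter. Compound 4 `COc1ccc(CN(C)CCCn2c(=O)oc3ccccc32)cc1` follows from compound 3 by 4-methoxyphenyl in place of 3-chlorophenyl on a saturated chain carbon bound to an amine nitrogen. The measured steps touching this aromatic ring are a 1.6-fold lower number from compound 1 to compound 2 (0.20 log units; within the scatter) and a 2.8-fold higher number from compound 2 to compound 3 (0.45 log units; beyond the scatter); the latter, exchanging 3-chlorophenyl for 4-chlorophenyl, bears most on the change. A modest downward step, a 2.3-fold lower number from compound 3 to compound 4 (0.36 log units; beyond the scatter), is therefore expected, placing compound 4 near the number of compound 2. Compound 4 is estimated at 1400 nM, with a range of 550 nM to 3600 nM.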

Compound 4, inhibition constant: 83 nM
Compound 4: the middle estimate sits 17-fold (1.23 log units) above what was measured; measured number outside the range, below it.
By their numbers in this assay, from the lowest: compound 4; then compounds 2, 1 and 3 (each within the scatter of the next, the first and the last beyond it).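

On the saturated chain carbon bound to an amine nitrogen, 4-methoxyphenyl separates clearly from the other three aromatic groups: a 39-fold lower number from compound 3 to compound 4 (1.59 log units; beyond the scatter), a 22-fold lower number from compound 1 to compound 4 (1.34 log units; beyond the scatter), and a 14-fold lower number from compound 2 to compound 4 (1.14 log units; beyond the scatter). Among the compounds shown here, that last step, methoxy in place of chloro on an aromatic carbon, exceeds every step among the earlier compounds, so the identity of the substituent moves this number far more than anything seen before. Nothing available explains the gain.

As far as these compounds go, whether it belongs to methoxy alone remains open. Groups such as 3-methoxyphenyl, 4-ethoxyphenyl or 4-hydroxyphenyl on the same carbon would test this.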